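From isopropyl to tert-butyl: a clearance estimate for compound 4

This account rests on a few compounds, and the source may have more. Where it says the series, first, only, none or still open, it means among the compounds named here.

In an in vitro ADME assay on microsomes from liver (Mus musculus) for pharmacokinetics, read by LC-MS, with a stated time of 10 min, tested at 1 uM (on this read-out lower numbers stand for slow clearance and higher numbers for fast clearance), compound 3 `CC(C)N1C[C@H](C(=O)Nc2ccc(Cl)cc2)[C@@H](c2ccc(/C=C/C(=O)Nc3ccccc3N)cc2)C1` gives 38 mL/min/kg. This value lies within the usual scatter of both other measured compounds, compound 1 `CN1C[C@H](C(=O)Nc2ccc(Cl)cc2F)[C@@H](c2ccc(/C=C/C(=O)Nc3ccccc3N)cc2)C1` at 43 mL/min/kg and compound 2 `CN1C[C@H](C(=O)NC2CCCC2)[C@@H](c2ccc(/C=C/C(=O)Nc3ccccc3N)cc2)C1` at 61 mL/min/kg. The next structure, compound 4 `CC(C)(C)N1C[C@H](C(=O)Nc2ccc(Cl)cc2)[C@@H](c2ccc(/C=C/C(=O)Nc3ccccc3N)cc2)C1`, carries one change: methyl in place of hydrogen on a saturated chain carbon bound to an amine nitrogen in a ring and two saturated chain carbons. Put simply, isopropyl becomes tert-butyl.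

Among the measured compounds shown here, the only measured single-place step is a 1.4-fold higher number from compound 1 to compound 2 (0.15 log units; within the scatter). It lies within the scatter, but it swaps a different group at a different place, so it bears on the new change only indirectly. Compound 1 and compound 3 differ in more than one place, so their values do not isolate this change either. The data therefore hold no direct precedent, and the small spread among the three values gives no reason to predict a large shift in this assay.

The expected change is a 1.1-fold higher number from compound 3 to compound 4 (0.04 log units; within the scatter), which would not stand out from the scatter. For compound 4 the estimated clearance is 42 mL/min/kg, with an expected range from 24 mL/min/kg to 72 mL/min/kg.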

Compound 4, clearance: 20 mL/min/kg
The estimate for compound 4 lay 2.1-fold (0.32 log units) above the measured number; the measured number lies below the stated range.
By their numbers in this assay, from the lowest: compounds 4, 3, 1 and 2 (each within the scatter of the next, the first and the last beyond it).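

Among the compounds shown here, this is the first step in the set that changes the group at this place, a saturated chain carbon bound to an amine nitrogen in a ring and two saturated chain carbons. In this assay, isopropyl to tert-butyl gives a 1.9-fold lower number from compound 3 to compound 4 (0.28 log units; within the scatter) and so cannot be told apart from repeat measurements, but it does show that this added methyl produces no shift beyond the scatter. Nothing measured here explains the number obtained for compound 4.

The compounds shown leave open how a cyclopropyl group, a longer chain such as n-butyl or a chain ending in a hydroxyl group would behave at this place. They also leave open whether isopropyl to tert-butyl would give a similar step alongside a different amide group, such as the cyclopentyl amide of compound 2.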